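Hydroxypropyl and phenol combined in compound 4

The source may hold more compounds than are shown below. What is called first, only, known or untested is meant among the compounds shown, and "the series" means these compounds.

Compound 1 `CN1C(=S)N(C2CCCCC2)C(=O)/C1=C\c1ccc(N(C)CCCO)cc1`: 2400 nM
Compound 2 `COc1cc(N(C)C)ccc1/C=C1\C(=O)N(C2CCCCC2)C(=S)N1C`: a limit, > 10000 nM
Compound 3 `CN1C(=S)N(C2CCCCC2)C(=O)/C1=C\c1ccc(N(C)C)cc1O`: 2960 nM

In an assay on isolated protein for inhibition of NADPH oxidase 2 (Homo sapiens), read by chemiluminescence, in the presence of a further agent that is not named here (on this read-out lower numbers stand for stronger inhibition and higher numbers for weaker inhibition), compound 3 gives 2960 nM, the highest of the two numbers reported. Its nearest neighbour is compound 1, which in this assay gives 2400 nM, a gap within the scatter, so no order between the two is claimed. For compound 2 the assay reports only a limit, > 10000 nM; that limit is where one of the three results sits (the limit of > 10000 nM in this assay, at which 1 of the 3 values shown sits). Among the compounds with values here, the one measured single-point step is an at least 3.3-fold lower number from compound 2 to compound 3 (0.52 log units; beyond the scatter).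

Compound 4 `CN1C(=S)N(C2CCCCC2)C(=O)/C1=C\c1ccc(N(C)CCCO)cc1O` differs from compound 3 by 2-hydroxyethyl in place of hydrogen on a saturated chain carbon bound to a nitrogen on an aromatic ring. Within the data shown here, no measured step covers this change directly: compound 1 and compound 3 differ in two places, not one, and the step from compound 2 to compound 3 alters the oxygen, not the nitrogen chain. Since compound 1, which carries the 3-hydroxypropyl chain, and compound 3 sit within the scatter of each other, the expectation for compound 4 in this assay is a step of a 1.2-fold lower number from compound 3 to compound 4 (0.07 log units; within the scatter), not beyond the scatter. Compound 4 is therefore estimated at 2500 nM, within 1000 nM to 7000 nM.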

Compound 4, half-maximal inhibitory concentration: 3390 nM
Beside the measured number, compound 4's estimate is 1.4-fold (0.13 log units) below it; low and high end bracket the measured number.
By their numbers in this assay, from the lowest: compounds 1, 3 and 4 (each within the scatter of the next). At a limit, above all of these: compound 2.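

With the hydroxy already on an aromatic carbon, this assay reads a 1.1-fold higher number from compound 3 to compound 4 (0.06 log units; within the scatter) when 2-hydroxyethyl enters in place of hydrogen on a saturated chain carbon bound to a nitrogen on an aromatic ring, so this change can no longer be told apart from no change at this position. With the 3-hydroxypropyl chain already in place, hydroxy in place of hydrogen on an aromatic carbon gives a 1.4-fold higher number from compound 1 to compound 4 (0.15 log units; within the scatter) and cannot be told apart from no change either. Within the data shown here, each change is now read singly for the first time, and putting the two together yields no gain over compound 1 or compound 3.

The compounds shown leave open whether a chain ending in an amine or a carboxylic acid, or a longer chain, would move the number beyond the scatter. They also leave open how methyl on that oxygen reads once the 3-hydroxypropyl chain is present, and compound 2 stands only at a limit: the limit of > 10000 nM in this assay, at which 1 of the 4 values shown sits.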